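A few compounds are considered here, and "the series" means these few. Any claim that something is new, unique, unknown or untested is made for them only; others in the source may bear on it.

Compound 1 `CN(C)c1cc2[nH]c(C3CCCCC3)nc2cc1NC(=O)c1ccc(Br)cc1` gives > 100 ug/mL in an ADME assay on Vero cells (Chlorocebus sabaeus) for cytotoxicity, read by resazurin assay, with a stated time of 3 days (a higher number here means a weaker inhibitor, a lower number a stronger inhibitor), a limit of the assay rather than a number. Compound 2 `O=C(Nc1cc2nc(C3CCCCC3)[nH]c2cc1N1CCCC1)c1ccc(Br)cc1` gives > 100 ug/mL in this assay, again only a limit. Compound 3 `CCN(CC)c1cc2[nH]c(C3CCCCC3)nc2cc1NC(=O)c1ccc(Br)cc1` gives > 100 ug/mL in this assay, once more a limit.

All three values shown therefore sit at the same point, as the Evidence puts it: the limit of > 100 ug/mL in this assay, at which 3 of the 3 values shown sit. Compound 2 stands at this limit along with the other two measured compounds, and nothing separates them on the numbers shown. The three steps among them, a step that the two limits leave unreadable from compound 1 to compound 2, a step that the two limits leave unreadable from compound 1 to compound 3 and a step that the two limits leave unreadable from compound 2 to compound 3, are all unreadable for this reason.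

The step now followed goes from compound 2 to compound 4 `O=C(NCc1ccccc1)Nc1cc2nc(C3CCCCC3)[nH]c2cc1N1CCCC1`, and its structural change is benzylamino in place of 4-bromophenyl on a carbonyl carbon. Among the compounds with values here, none of the measured steps bears on this change, since each of them moves only the amine on an aromatic carbon, while this one replaces the 4-bromophenyl on the carbonyl carbon by benzylamino. With every measured value at the limit, the only expectation the data support is that compound 4 also stays at the limit in this assay, so that no step beyond the scatter is expected; the step from compound 2 to compound 4 is estimated as a number no higher from compound 2 to compound 4 (the limit leaves the size open). Compound 4 is accordingly expected at 100 ug/mL, with a range from 50 ug/mL to 200 ug/mL.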

Compound 4, half-maximal inhibitory concentration: > 100 ug/mL
Compound 4: a limit, no number; the forecaster's own chance of this, stated with the estimate: 85%; the middle value sits exactly at the limit.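

In this assay compound 4 gives > 100 ug/mL, which is a limit. No size can be read for the step from compound 2 to compound 4, because both stand at the same limit: the limit of > 100 ug/mL in this assay, at which 4 of the 4 values shown sit.

The compounds shown leave open how far each lies from that limit, and whether benzylamino and 4-bromophenyl on the carbonyl carbon differ at all in this assay.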